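Replacing 2,6-dimethoxyphenyl with 2,4-dichlorophenyl on a shared core

A few compounds are considered here, and "the series" means these few. Any claim that something is new, unique, unknown or untested is made for them only; others in the source may bear on it.

Of the compounds shown here, three sharing one core have been tested in a functional assay on PC-3 cells (Homo sapiens) for inhibition, read by sulforhodamine B assay, with a stated time of 48 h; a lower number here means a stronger inhibitor of growth, a higher number a weaker inhibitor of growth. Compound 1 (`O=C(Cc1csc2nc(-c3ccc(Br)cc3)cn12)N/N=C/c1ccccc1O`), which carries 2-hydroxyphenyl, gives a reading of 4270 nM in this series. Compound 2 (`O=C(Cc1csc2nc(-c3ccc(Br)cc3)cn12)N/N=C/c1ccc(O)cc1`), which carries 4-hydroxyphenyl, is reported only as a limit (> 10 nM) and not as a number. Its steps to the other two compounds therefore cannot be sized, as with this one (a step that the limit leaves unreadable from compound 1 to compound 2) and this one (a step that the limit leaves unreadable from compound 2 to compound 3). Compound 3 (`COc1cccc(OC)c1/C=N/NC(=O)Cc1csc2nc(-c3ccc(Br)cc3)cn12`), which carries 2,6-dimethoxyphenyl, gives 13500 nM as the higher of the two readable numbers, and compound 1 is its nearest neighbour.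

Compound 4 (`O=C(Cc1csc2nc(-c3ccc(Br)cc3)cn12)N/N=C/c1ccc(Cl)cc1Cl`) differs from compound 3 in a single place (2,4-dichlorophenyl in place of 2,6-dimethoxyphenyl on a carbon with a double bond to nitrogen), with 2,4-dichlorophenyl in place of 2,6-dimethoxyphenyl on a carbon with a double bond to nitrogen. Within the data shown here, no tested compound carries 2,4-dichlorophenyl, so the only guide is the one readable step at this place, which is modest (a 3.2-fold higher number from compound 1 to compound 3 (0.50 log units; beyond the scatter)). A change of no greater size is therefore expected here, towards a lower number, within the span the two readable compounds mark out. The expected step is small (a 2.3-fold lower number from compound 3 to compound 4 (0.35 log units; beyond the scatter)). In this assay compound 4 is estimated at 6000 nM (expected range 1800 nM to 20000 nM).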

Compound 4, concentration for 50% growth inhibition: 30200 nM
Compound 4: middle estimate off by 5.0-fold (0.70 log units), on the low side; measured number above the stated range.
By their numbers in this assay, from the lowest: compound 1; then compound 3; then compound 4.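

On the carbon with a double bond to nitrogen, 2,4-dichlorophenyl in place of 2,6-dimethoxyphenyl gives, in this assay, a 2.2-fold higher number from compound 3 to compound 4 (0.35 log units; beyond the scatter), so this change moves the reading up, and compound 4 now holds the highest of the readable numbers. The readable span at this place also widens, to a 7.1-fold higher number from compound 1 to compound 4 (0.85 log units; beyond the scatter), a step that is still modest, and 2-hydroxyphenyl keeps the lowest of the three readable numbers. Both groups without a hydroxy group now read higher than 2-hydroxyphenyl, a pattern that rests on compound 1, compound 3 and compound 4 alone.

Compound 2, the other hydroxy compound, is reported only as a limit, so none of its steps can be read and it can neither support nor contradict that pattern: the limit of > 10 nM in this assay, at which 1 of the 4 values shown sits. Also open is how the reading would respond at this place to an aminophenyl group, or to a phenyl ring carrying a carboxylic acid, since the groups shown offer no guide to either.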